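Aryl swap on the shared core: compound 3 to compound 4

The source may hold more compounds than are shown below. What is called first, only, known or untested is meant among the compounds shown, and "the series" means these compounds.

Values in an assay on NIH3T3 cells for inhibition of Sonic hedgehog protein (Mus musculus), read by a luciferase reporter, with a stated time of 48 h; a higher number here means a weaker inhibitor, a lower number a stronger inhibitor:
Compound 1 `Cc1cnc(Nc2ccc3[nH]ncc3c2)nc1-c1ccc(OC(F)(F)F)cc1`: 125 nM
Compound 2 `Cc1ccccc1C(=O)Nc1ccc(Nc2ncc(C)c(-c3ccc(OC(F)(F)F)cc3)n2)cc1`: 42.1 nM
Compound 3 `Cc1cnc(Nc2ccc(C(=O)Nc3c(C)cccc3C)cc2)nc1-c1cccc(OC(F)(F)F)c1`: 1.2 nM

Compound 3 has the lowest number of the three in this assay, beyond the scatter against compound 2 and further still against compound 1. Compound 4 `Cc1cnc(Nc2ccc(C(=O)Nc3c(C)cccc3C)cc2)nc1-c1ccc(C#N)cc1` keeps the rest of compound 3 and changes one piece: 4-cyanophenyl in place of 3-(trifluoromethoxy)phenyl on an aromatic carbon. Among the measured compounds shown here, no pair differing at this position has been measured, so the size of the step is unknown. A modest weakening is expected, as the step from compound 3 to compound 4 of a 4.2-fold higher number from compound 3 to compound 4 (0.62 log units; beyond the scatter); compound 4 is estimated at 5 nM, within 1.2 nM to 25 nM.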

Compound 4, half-maximal inhibitory concentration: 2.8 nM
Compound 4: middle estimate off by 1.8-fold (0.25 log units), on the high side, within the range that was stated.
By their numbers in this assay, from the lowest: compound 3; then compound 4; then compound 2; then compound 1.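

In this assay, among the compounds shown here, the first readable step at this aryl position is a 2.3-fold higher number from compound 3 to compound 4 (0.37 log units; beyond the scatter) on going from 3-(trifluoromethoxy)phenyl to 4-cyanophenyl. Strong inhibition therefore does not depend on the trifluoromethoxy group: with both the substituent and its place on the phenyl ring changed, compound 4 still gives 2.8 nM in this assay. Nothing available bears on the reason for this step.

Going by these compounds, with both features changing together, their separate contributions remain open; 3-cyanophenyl and 4-(trifluoromethoxy)phenyl would separate them on this core. Also open, on these data alone, is how an amine or a carboxylic acid on this phenyl ring would compare.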